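The source may report more compounds than this note shows. Statements on the series, on what has been measured and on what is new or still open speak of the compounds shown alone.

Measured compounds, with their values:

- Compound 2 `COc1cc(Cl)cc(-c2nn(-c3cccc(NC(=O)Nc4ccc(Cl)c(C(F)(F)F)c4)c3)cc2-c2ccncc2)c1` — 93%
- Compound 1 `O=C(Nc1cccc(-n2cc(-c3ccncc3)c(-c3cc(O)cc(Cl)c3)n2)c1)Nc1ccc(Cl)c(C(F)(F)F)c1` — 105%
- Compound 3 `COc1cc(Cl)cc(-c2nn(-c3cccc(NC(=O)Nc4cc(C(F)(F)F)cc(C(F)(F)F)c4)c3)cc2-c2ccncc2)c1` — 97%

For the measured compounds named here, in a functional assay on MDA-MB-231 cells (Homo sapiens) for inhibition, read by sulforhodamine B assay, with a stated time of 48 h, tested at 0.01 uM (on this read-out lower numbers stand for a stronger effect and higher numbers for a weaker effect at the one concentration tested), compound 2 gives 93%, the lowest of the three numbers; compound 3 gives 97%, which lies within the scatter of compound 2, and compound 1 gives 105%, the only number beyond the scatter from compound 2. Going by the values given here, the one step between compounds that differ in one place is a number 12 percentage points lower from compound 1 to compound 2 (beyond the scatter), a modest change for a methyl in place of hydrogen on an oxygen on an aromatic ring.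

The unmeasured compound 4 `COc1cc(Cl)cc(-c2nn(-c3cccc(NC(=O)c4cccc(C(F)(F)F)c4)c3)cc2-c2ccncc2)c1` differs from compound 2 by 3-(trifluoromethyl)phenyl in place of (4-chloro-3-(trifluoromethyl)phenyl)amino on a carbonyl carbon. Among the compounds with values here, no measured step alters the carbonyl carbon or its neighbours, so the step from compound 1 to compound 2 does not bear on this change; all three measured numbers, compounds 1, 2 and 3, sit close together at this concentration. The expected step in this assay from compound 2 to compound 4 is therefore a number 5 percentage points higher from compound 2 to compound 4 (within the scatter), not beyond the scatter in either direction. Compound 4 is estimated at 98%, with a range of 85% to 112%.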

Compound 4, a percentage reported as activity, at one concentration (the size of the read-out at that concentration, not a potency): 102%
Beside the measured number, compound 4's estimate is 4 percentage points below it; the measured number falls inside the stated range.
By their numbers in this assay, from the lowest: compounds 2, 3, 4 and 1 (each within the scatter of the next, the first and the last beyond it).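

In this assay, 3-(trifluoromethyl)phenyl in place of (4-chloro-3-(trifluoromethyl)phenyl)amino on a carbonyl carbon gives a number 9 percentage points higher from compound 2 to compound 4 (within the scatter), the first step shown at this position. The change removes the hydrogen-bond donor and the chlorine of the leaving group, along with two heavy atoms overall, yet at this single low concentration the read-out does not separate the two compounds. No supporting data bear on the reason for this step.

Going by these compounds, it remains open whether another group on this carbonyl carbon, such as a piperidine amine or a longer alkyl chain, would shift the number beyond the scatter. Also open, on these data alone, is whether compound 2 and compound 4 would still lie this close at higher concentrations, where a fuller response could separate them.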